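The source may report more compounds than this note shows. Statements on the series, on what has been measured and on what is new or still open speak of the compounds shown alone.

Three compounds share one core and differ only in the group on the carbonyl carbon. Compound 1 `COc1ccc(-c2cc(/C=C/C(=O)c3ccc(N)cc3)[nH]n2)cc1` gives -61% in a functional assay on SF-268 cells (Homo sapiens) for cytotoxicity, read by sulforhodamine B assay, with a stated time of 48 h, tested at 100 uM (on this read-out higher numbers stand for a weaker effect at the one concentration tested and lower numbers for a stronger effect), compound 2 `COc1cc(-c2cc(/C=C/C(=O)c3ccc(N)cc3)[nH]n2)cc(OC)c1OC` gives -80%, and compound 3 `COc1cc(-c2cc(/C=C/C(=O)c3ccc(Cl)c(Cl)c3)[nH]n2)cc(OC)c1OC` gives -15%. Compound 3 therefore stands highest of the three numbers, beyond the scatter from both others, meaning the weakest effect at the single concentration tested. The step of a number 65 percentage points higher from compound 2 to compound 3 (beyond the scatter) shows that this position can shift the number a great deal. Compound 4 `COc1cc(-c2cc(/C=C/C(=O)c3ccc(F)c(F)c3)[nH]n2)cc(OC)c1OC` carries 3,4-difluorophenyl in place of 3,4-dichlorophenyl on a carbonyl carbon. Among the measured compounds shown here, no measured step exchanges one halogen pair for another, so only a modest move is expected. Compound 4 is estimated at -25%, within a range from -55% to 5%. This expectation means a step of a number 10 percentage points lower from compound 3 to compound 4 (within the scatter).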

Compound 4, a percentage reported as activity, at one concentration (the size of the read-out at that concentration, not a potency): 1%
Compound 4: the middle estimate sits 26 percentage points below what was measured; low and high end bracket the measured number.
By their numbers in this assay, from the lowest: compound 2; then compound 1; then compound 3; then compound 4.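

The change from one halogen pair to the other is not silent at this position on the carbonyl carbon: it gives a number 16 percentage points higher from compound 3 to compound 4 (beyond the scatter), a modest step but one beyond the scatter. The much larger a number 81 percentage points higher from compound 2 to compound 4 (beyond the scatter) shows that 3,4-difluorophenyl, like 3,4-dichlorophenyl, reads far from 4-aminophenyl, so among these compounds, replacing the amino-bearing ring matters more than which halogen pair is present. Nothing shown here explains these differences. Still open, from the compounds shown here alone, is how a plain phenyl group would read on this carbonyl carbon, and whether 3,4-difluorophenyl would give a similar number on the core of compound 1.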